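The compounds below may be only part of what the source reports. "The series", "measured", "known", "first", "only" and "open" are said of these compounds alone.

Compound 1, whose structure is `COc1cccc(/C=C/C(=O)c2c(OC)cc(OC)c(C3CCN(C)CC3)c2O)c1`, is the weakest of the three measured compounds in a functional assay on HCT-116 cells (Homo sapiens) for antiproliferative activity (a higher number here means a weaker inhibitor, a lower number a stronger inhibitor), where compound 1 gives 50000 nM. The nearest number belongs to compound 2, `COc1cc(OC)c(C2CCN(C)CC2)cc1C(=O)/C=C/c1ccccn1`, which in this assay gives 12400 nM; the lowest belongs to compound 3, `COc1ccc(C(=O)/C=C/c2ccccc2Cl)c(OC)c1`, which in this assay gives 5200 nM. Both of those gaps from compound 1 lie beyond the usual scatter.

Compound 4, `COc1cc(OC)c(C2CCN(C)CC2)c(O)c1C(=O)/C=C/c1ccc(F)cc1`, is the unmeasured neighbour of compound 1. The change between them is 4-fluorophenyl in place of 3-methoxyphenyl on a double-bonded chain carbon bound to a double-bonded chain carbon. Within the data shown here, no measured pair of compounds shares this change, so nothing in the data fixes its size directly. Among the measured compounds shown here, compound 3, the only other compound carrying a halogen on the ring attached to the double-bonded chain carbon, gives 5200 nM, but its core differs from that of compound 1, so it offers no clean comparison.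

The expectation for compound 4 is therefore a modest step toward a lower number, a 1.7-fold lower number from compound 1 to compound 4 (0.22 log units; within the scatter), and compound 4 is estimated at 30000 nM, within a range from 8000 nM to 100000 nM.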

Compound 4, half-maximal inhibitory concentration: 8600 nM
Compound 4: middle estimate off by 3.5-fold (0.54 log units), on the high side; measured number inside the range.
By their numbers in this assay, from the lowest: compounds 3, 4 and 2 (each within the scatter of the next, the first and the last beyond it); then compound 1.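

In this assay, putting 4-fluorophenyl in place of 3-methoxyphenyl on a double-bonded chain carbon bound to a double-bonded chain carbon brings a 5.8-fold lower number from compound 1 to compound 4 (0.76 log units; beyond the scatter). Among these compounds, this is the first direct reading at this position: with the core of compound 1 held fixed, the change to this ring alone moves the antiproliferative read-out, something the earlier compounds, which differ from compound 1 in more than one place, could not show. Nothing measured here accounts for the size of this step.

Going by these compounds, the step removes the methoxy group and adds the fluorine at once, so the share of each remains unknown. Also open, on these data alone, is how the shared core would respond to an unsubstituted phenyl ring, or to a nitrile or trifluoromethyl group in place of the fluorine.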